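The compounds below may be only part of what the source reports. "The series", "measured", "known", "first", "only" and "open" are said of these compounds alone.

Measured so far in a functional assay (aorta) for inhibition, with Rattus norvegicus as the target, with a stated time of 8 days; on this read-out lower numbers stand for stronger inhibition and higher numbers for weaker inhibition:

- compound 1 `Cc1nsc(-c2ccnc(N3CCN(c4cccc(C(F)(F)F)c4)CC3)n2)n1`: > 100 nM
- compound 2 `CCc1nsc(-c2ccc(N3CCN(c4cccc(C(F)(F)F)c4)CC3)nn2)n1`: 8 nM

Among the measured compounds shown here, compound 2 gives 8 nM, the only true number in this small set. Compound 1 has only a limit, > 100 nM, and not a number. The two compounds differ in more than one place, so their values alone do not tie the result to any single feature.

The next compound is compound 3 `Cc1nsc(-c2ccc(N3CCN(c4cccc(C(F)(F)F)c4)CC3)nn2)n1`, still to be measured. Its difference from compound 2 is hydrogen in place of methyl on a saturated chain carbon bound to an aromatic carbon, which turns the ethyl into a methyl. For the measured compounds named here, no measured pair in this set shows what such a change does in this assay. The expectation therefore starts from compound 2 and its 8 nM, and only a modest shift is foreseen, if any. The estimated step of a 1.5-fold higher number from compound 2 to compound 3 (0.18 log units; within the scatter) points towards slightly weaker inhibition and is expected to stay within the usual scatter. For compound 3 the estimated value is 12 nM, with an expected range from 4 nM to 40 nM.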

Compound 3, half-maximal inhibitory concentration: 0.3 nM
Estimate against measurement, compound 3: 40-fold (1.60 log units) above; measured number outside the range, below it.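

In this assay, the change from ethyl to methyl gives a 27-fold lower number from compound 2 to compound 3 (1.43 log units; beyond the scatter), which means stronger inhibition from a difference of just 1 carbon on the 1,2,4-thiadiazole group. Among the compounds shown here, this is the first comparison in the set that isolates a single change, and it shows that the read-out is highly sensitive to the chain at this position, so a small edit here cannot be assumed to be harmless. The values shown include no measurement that explains this step, which therefore stands as an observation about one pair of compounds and not as a general rule.

As far as these compounds go, only ethyl and methyl can be compared here, so it remains open how strong the inhibition would be with a hydrogen atom in place of the whole methyl, with a longer chain such as propyl, or with an amine at the same place. From the compounds shown here alone, it also remains open whether going from ethyl to methyl would have a similar effect on the different core of compound 1.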